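Configuration change within a cytotoxicity series

This account rests on a few compounds, and the source may have more. Where it says the series, first, only, none or still open, it means among the compounds named here.

Working notes on a small set measured in a functional assay on HCT-8 cells (Homo sapiens) for cytotoxicity, read by MTT assay; on this read-out higher numbers stand for weaker inhibition and lower numbers for stronger inhibition. Compound 1, `CC(=O)C1=C[C@@H]2[C@H](C(C)C)CC[C@@H](C)[C@]2(O)C1`, was measured in this assay. In this assay compound 1 gives > 10 ug/mL, which is a limit of the assay and not a number. Compound 2, `CC(=O)[C@H]1C[C@]2(O)[C@@H]([C@@H]1O)[C@H](C(C)C)CC[C@H]2C`, shares the same read-out. In this assay compound 2 gives > 10 ug/mL, again a limit of the assay rather than a number. So compound 2 stands where every value so far stands: the limit of > 10 ug/mL in this assay, at which 2 of the 2 values shown sit.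

The next compound is compound 3, `CC(=O)[C@@H]1C[C@]2(O)[C@@H]([C@H]1O)[C@H](C(C)C)CC[C@H]2C`. It differs from compound 2 only in configuration: the two compounds have the same atoms and bonds and differ only in configuration as drawn: 2 of 6 stereo elements differ; a stereocentre at a saturated ring carbon is drawn S in compound 2 and R in compound 3; a stereocentre at a saturated ring carbon is drawn S in compound 2 and R in compound 3.

Among the measured compounds shown here, no step between measured compounds exists in this set, so the size of the move is not known from data. Given that compound 2 sits only at the limit > 10 ug/mL, the step that the limit leaves unreadable from compound 2 to compound 3 is expected to stay within the scatter, with no direction that can be read from the numbers. Compound 3 is therefore estimated at 15 ug/mL, with a range from 5 ug/mL to 50 ug/mL, and a limit rather than a number is the most likely outcome.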

Compound 3, half-maximal inhibitory concentration: > 10 ug/mL
Compound 3: only a limit was reported; the forecaster's own chance of this, stated with the estimate: 75%; the middle value is on the limit's open side.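

Compound 2 and compound 3 both sit at a limit of the assay and not at a number, so no step can be read between them: the limit of > 10 ug/mL in this assay, at which 3 of the 3 values shown sit.

The compounds shown leave open whether any change to the shared core, this change of configuration included, would give a measurable value rather than a limit.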